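Swapping a chloro for a carboxy on the benzyl ring

This account rests on a few compounds, and the source may have more. Where it says the series, first, only, none or still open, it means among the compounds named here.

Of the compounds shown here, three sharing one core have been measured in a functional assay on BT-20 cells (Homo sapiens) for antiproliferative activity, read by trypan blue exclusion; a higher number here means a weaker inhibitor, a lower number a stronger inhibitor. Compound 1 `COc1cc(OC)c(/C=C/S(=O)(=O)Cc2ccc(OC)c(OP(=O)(O)O)c2)c(OC)c1` gives 5 nM, compound 2 `COc1cc(OC)c(/C=C/S(=O)(=O)Cc2ccc(OC)c(OC)c2OC)c(OC)c1` gives 15000 nM, and compound 3 `COc1cc(OC)c(/C=C/S(=O)(=O)Cc2ccc(Cl)cc2)c(OC)c1` gives 10000 nM. Compound 3 therefore holds the second highest of the three numbers: its value lies within the usual scatter of that of compound 2, so no order between these two can be claimed, while compound 1 sits far lower, well beyond the scatter.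

Compound 4 `COc1cc(OC)c(/C=C/S(=O)(=O)Cc2ccc(C(=O)O)cc2)c(OC)c1` differs from compound 3 in one place: carboxy in place of chloro on an aromatic carbon. The new group sits on an aromatic carbon of a six-membered aromatic ring of carbon only, para to a large group. Among the compounds with values here, no pair of measured compounds shows this kind of exchange, and compound 1, the only strong inhibitor, differs from compound 3 in several places at once, so it offers no direct guide.

With nothing to lean on, compound 4 is expected to move little, a step of a 2.0-fold higher number from compound 3 to compound 4 (0.30 log units; within the scatter) in this assay. The estimate for compound 4 is 20000 nM, with a range from 3000 nM to 100000 nM.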

Compound 4, half-maximal inhibitory concentration: 15000 nM
Beside the measured number, compound 4's estimate is 1.3-fold (0.12 log units) above it; low and high end bracket the measured number.
By their numbers in this assay, from the lowest: compound 1; then compounds 3, 2 and 4 (each within the scatter of the next).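

In this assay, within the data shown here, carboxy in place of chloro gives a 1.5-fold higher number from compound 3 to compound 4 (0.18 log units; within the scatter), the first single exchange that can be read. On this aromatic carbon, para to a large group, the two compounds cannot be told apart, even though the entering carboxy brings more heavy atoms, a hydrogen-bond donor and a hydrogen-bond acceptor, none of which the chloro has. Nothing measured here explains this outcome.

On these data alone, whether any group on this carbon can give a clearly different number stays open, for an amine, a hydroxy group or a primary amide, for example. Also open, as far as these compounds go, is whether the same exchange would read alike on a benzyl ring carrying the groups of compound 1, which gives 5 nM.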